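Replacing the morpholine thioamide substituent in compound 1

This account rests on a few compounds, and the source may have more. Where it says the series, first, only, none or still open, it means among the compounds named here.

Compound 1 `N/C(=N\NC(=S)N1CCOCC1)c1ccccn1` gives 78.8% in a functional assay on A-431 cells (Homo sapiens) for cytotoxicity, read by MTT assay, with a stated time of 72 h, tested at 30 uM; a lower number here means less inhibition of growth, a higher number more inhibition of growth at the concentration tested. Among the three measured values it is the second highest: compound 3 `N/C(=N\NC(=S)N1CCOCC1)c1ccc(F)cn1` gives 82.3%, and compound 2 `Cc1ccnc(/C(N)=N/NC(=S)N2CCOCC2)c1` gives 74.6%. Both steps away from compound 1 stay within the scatter, a number 3.5 percentage points higher from compound 1 to compound 3 (within the scatter) and a number 4.2 percentage points lower from compound 1 to compound 2 (within the scatter), and both change the aromatic ring of the shared core, not the thiocarbonyl side.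

Compound 4 `N/C(=N\NC(=S)N1CCCC1)c1ccccn1` differs from compound 1 by pyrrolidin-1-yl in place of morpholin-4-yl on a thiocarbonyl carbon. For the measured compounds named here, no measured step touches this position, so the series offers no direct guide to size or direction. Going by the values given here, the only precedent is that single substitutions elsewhere in compound 1 left this assay within the scatter, which weakly suggests a step of similar scale, though it says nothing firm about a change on the thiocarbonyl carbon. For compound 4 the estimate in this assay is 75%, with a range of 55% to 92%. The expected step is a number 3.8 percentage points lower from compound 1 to compound 4 (within the scatter), taken as not beyond the scatter.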

Compound 4, percent growth inhibition at one concentration: 85.2%
For compound 4 the middle estimate is 10.2 percentage points below the measured one; the measured number falls inside the stated range.
By their numbers in this assay, from the lowest: compounds 2, 1, 3 and 4 (each within the scatter of the next, the first and the last beyond it).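

In this assay, for the compounds shown here, the first step on the thiocarbonyl carbon, pyrrolidin-1-yl in place of morpholin-4-yl, is a number 6.4 percentage points higher from compound 1 to compound 4 (within the scatter). The thiocarbonyl side therefore joins the aromatic ring as a place where a single change in compound 1 stays within the scatter, and the loss of the morpholine oxygen, with its one hydrogen-bond acceptor, leaves growth inhibition at the concentration tested without a change that can be told from the scatter. No supporting evidence bears on why this substitution gives this result.

Still open, going by these compounds, is how this position responds to piperidin-1-yl, to an open-chain dimethylamino group, or to piperazin-1-yl with its second ring nitrogen. Also open, on these data alone, is whether pyrrolidin-1-yl gives a similar reading when combined with the fluoro or methyl group on the aromatic ring.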